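A few compounds are considered here, and "the series" means these few. Any claim that something is new, unique, unknown or untested is made for them only; others in the source may bear on it.

In a functional assay on MCF7 cells (Homo sapiens) for inhibition, read by MTT assay, with a stated time of 72 h (on this read-out higher numbers stand for weaker inhibition and lower numbers for stronger inhibition), compound 1 `Nc1ccccc1NC(=O)c1ccc(CNC(=O)/C=C/c2cnc3ccccn23)cc1` gives 4130 nM and compound 2 `Nc1ccc(F)cc1NC(=O)c1ccc(CNC(=O)/C=C/c2cnc3cccnn23)cc1` gives 11000 nM. Compound 2 therefore holds the higher of the two numbers, and its gap to compound 1 lies beyond the scatter. The next entry is compound 3 `Nc1ccccc1NC(=O)c1ccc(CNC(=O)/C=C/c2cnc3cccnn23)cc1`, which carries hydrogen in place of fluoro on an aromatic carbon, para to an amino group: hydrogen in place of fluoro on an aromatic carbon. Going by the values given here, no measured pair isolates this change, so the data give no direct measure of its size. A small move toward stronger inhibition in this assay is expected, possibly no larger than the scatter, with compound 1 at 4130 nM as the only lower reference point. The expected change is a 1.6-fold lower number from compound 2 to compound 3 (0.20 log units; within the scatter). For compound 3, the estimated value is 7000 nM, with an expected range of 3000 nM to 15000 nM.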

Compound 3, half-maximal inhibitory concentration: 2870 nM
Compound 3: the middle estimate sits 2.4-fold (0.39 log units) above what was measured, and the stated range ends above it.
By their numbers in this assay, from the lowest: compounds 3 and 1 (each within the scatter of the next); then compound 2.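

In this assay the position para to an amino group proves sensitive: hydrogen in place of fluoro gives a 3.8-fold lower number from compound 2 to compound 3 (0.58 log units; beyond the scatter), so 2-aminophenyl is preferred over 2-amino-5-fluorophenyl on this core. The other step, on the double-bonded chain carbon, reads a 1.4-fold lower number from compound 1 to compound 3 (0.16 log units; within the scatter) and separates neither compound, which ties the high number of compound 2 to the fluoro rather than to the exchanged group. Nothing measured here bears on why the fluoro costs activity.

Going by these compounds alone, still open is whether the fluoro step recurs on the core of compound 1, since only one pair isolates it. Equally open, from the compounds shown here alone, is how chloro, methyl or methoxy would behave at this same position, and so whether the loss is specific to fluoro or extends to other groups there.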